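The source may report more compounds than this note shows. Statements on the series, on what has been measured and on what is new or still open speak of the compounds shown alone.

In a physicochemical assay, with a stated time of 30 min (a higher number here means a weaker inhibitor, a lower number a stronger inhibitor), compound 1 `COc1cc2c(cc1OC)C(=O)C(C(=O)Nc1ccccc1)C2` gives 61.3 ug/mL, and compound 2 `COc1cccc(NC(=O)C2Cc3cc(OC)c(OC)cc3C2=O)c1` gives 38.9 ug/mL. For the measured compounds named here, compound 2 has the lower of only two numbers, but the two sit within the scatter of each other, so it cannot be ranked with confidence. Compound 3 `COc1cc2c(cc1OC)C(=O)C(C(=O)Nc1cccc(Br)c1)C2` keeps the shared core and places bromo in place of methoxy on an aromatic carbon, meta to a large group, turning 3-methoxyphenyl into 3-bromophenyl (bromo in place of methoxy on an aromatic carbon). Going by the values given here, only one measured step bears on this change, the one that introduced the same methoxy: a 1.6-fold lower number from compound 1 to compound 2 (0.20 log units; within the scatter). Among the compounds with values here, no measured compound yet carries bromo, so the data offer only a weak guide. The expected change in this assay is therefore none beyond the scatter, and the estimated step is a 1.2-fold higher number from compound 2 to compound 3 (0.06 log units; within the scatter). For compound 3 the estimated value is 45 ug/mL, with an expected range from 20 ug/mL to 95 ug/mL.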

Compound 3, half-maximal inhibitory concentration: 58.9 ug/mL
Estimate against measurement, compound 3: 1.3-fold (0.12 log units) below; measured number inside the range.
By their numbers in this assay, from the lowest: compounds 2, 3 and 1 (each within the scatter of the next).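

At this aromatic carbon, meta to a large group, bromo in place of methoxy gives a 1.5-fold higher number from compound 2 to compound 3 (0.18 log units; within the scatter) and bromo in place of hydrogen gives a 1.0-fold lower number from compound 1 to compound 3 (0.02 log units; within the scatter) in this assay here. With hydrogen, methoxy and bromo now compared at the same place, no step among these three compounds rises above the scatter, so this read-out does not separate them and the three groups cannot be put in any order. Nothing measured here speaks to what lies behind these numbers.

Going by these compounds, it remains open whether a different kind of group at this place, such as an amine or a carboxylic acid, would shift the number beyond the scatter. On these data alone, it also remains open whether a change elsewhere on the shared core would matter more than any change at this position.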